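Two More Chain Carbons on a Tosyl Threonine Amide

The compounds below may be only part of what the source reports. "The series", "measured", "known", "first", "only" and "open" are said of these compounds alone.

Compound 1, `CCCCCCCCCCCCNC(=O)[C@@H](NC(=O)c1ccco1)[C@@H](C)O`: 147000 nM
Compound 2, `CCCCCCCCCCCCNC(=O)[C@@H](NC(=O)c1cccs1)[C@@H](C)O`: 30100 nM
Compound 3, `CCCCCCCCCCCCNC(=O)[C@@H](NS(=O)(=O)c1ccc(C)cc1)[C@@H](C)O`: 25800 nM

All three were tested in a functional assay on HepG2 cells (Homo sapiens) for cytotoxicity, read by MTT assay, with a stated time of 48 h; a higher number here means a weaker inhibitor, a lower number a stronger inhibitor. Compound 3 is set apart from compound 1 by a 5.7-fold lower number from compound 1 to compound 3 (0.76 log units; beyond the scatter), while its distance from compound 2, a 1.2-fold lower number from compound 2 to compound 3 (0.07 log units; within the scatter), is within the scatter, so these two cannot be ranked. The remaining step, a 4.9-fold lower number from compound 1 to compound 2 (0.69 log units; beyond the scatter), also concerns only the group on the amine nitrogen.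

Compound 4, `CCCCCCCCCCCCCCNC(=O)[C@@H](NS(=O)(=O)c1ccc(C)cc1)[C@@H](C)O`, differs from compound 3 by ethyl in place of hydrogen on a saturated chain carbon, ten or more bonds along the chain from an amide-type nitrogen. Among the measured compounds shown here, no measured step touches this chain, so nothing measured bears directly on the change. With no anchor, the step is expected to stay within the scatter. Compound 4 is therefore expected near 20000 nM, in the range 7000 nM to 60000 nM, which means an expected 1.3-fold lower number from compound 3 to compound 4 (0.11 log units; within the scatter).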

Compound 4, half-maximal inhibitory concentration: 10900 nM
The estimate for compound 4 lay 1.8-fold (0.26 log units) above the measured number; measured number inside the range.
By their numbers in this assay, from the lowest: compound 4; then compounds 3 and 2 (each within the scatter of the next); then compound 1.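

In this assay ethyl in place of hydrogen on a saturated chain carbon, ten or more bonds along the chain from an amide-type nitrogen, gives a 2.4-fold lower number from compound 3 to compound 4 (0.37 log units; beyond the scatter) and so shows, though only modestly, that the read-out responds to this part of the chain. The earlier compounds shown here changed only the group on the amine nitrogen. Nothing shown explains this step.

As far as these compounds go, whether a longer chain would lower the number further remains open. So does whether the same ethyl change would hold with the furan-2-yl or thiophen-2-yl carbonyl groups.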